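Swapping the aryl ether of compound 1 for a saturated ether

The source may report more compounds than this note shows. Statements on the series, on what has been measured and on what is new or still open speak of the compounds shown alone.

Among the compounds with values here, compound 1, `CC(C)(C)C#Cc1cc(N(C(=O)[C@H]2CC[C@H](C)CC2)[C@H]2CC[C@H](Oc3ccccn3)CC2)c(C(=O)O)s1`, is the one anchor of this series: in a physicochemical assay for lipophilicity (a higher number here means a more lipophilic compound, a lower number a more polar compound), compound 1 gives 3, the only number on hand. Compound 2, `CC(C)(C)C#Cc1cc(N(C(=O)[C@H]2CC[C@H](C)CC2)[C@H]2CC[C@@](O)(CO[C@H]3CCOC3)CC2)c(C(=O)O)s1`, belongs to the same series, but for compound 2 the outcome in this assay is recorded as "not determined" (no result reported), so it offers no comparison.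

Compound 3, `CC(C)(C)C#Cc1cc(N(C(=O)[C@H]2CC[C@H](C)CC2)[C@H]2CC[C@H](OC3CCOC3)CC2)c(C(=O)O)s1`, differs from compound 1 in a single place: oxolan-3-yl in place of pyridin-2-yl on an oxygen on a saturated carbon. Cut one bond further out, the change reads (pyridin-2-yl)oxy to (oxolan-3-yl)oxy; the six-membered aromatic ring with one hetero atom leaves and a five-membered non-aromatic ring with one hetero atom enters, with the count of donors and acceptors unchanged.

Within the data shown here, no measured pair spans this kind of change, so the size of the step rests on the structures alone. The step from compound 1 to compound 3 in this assay is expected to be a number 0.70 log units lower from compound 1 to compound 3 (beyond the scatter), a move downward that should exceed the scatter, though not by a wide margin. For compound 3 the estimated value in this assay is 2.3, within a range from 1.6 to 3.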

Compound 3, distribution coefficient: 2.3
The estimate for compound 3 equals the measured number at the digits printed; measured number inside the range.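

The position on the oxygen on a saturated carbon now has a measured step: in this assay, oxolan-3-yl in place of pyridin-2-yl gives a number 0.70 log units lower from compound 1 to compound 3 (beyond the scatter) and so registers as a real change rather than scatter. The counts of hydrogen-bond donors and acceptors are the same on both sides of this swap, so a step of this size can occur at this position with those counts held constant. No available evidence bears on why the step has this size.

On these data alone, this single step changes aromatic character, ring size and the hetero atom together, so the part each one plays remains open, and a phenyl, cyclopentyl or oxan-4-yl group on the same oxygen would be needed to separate them. As far as these compounds go, whether the read-out keeps moving with a further change at this place, such as a ring carrying an amine or a hydroxyl group, also remains open, and compound 2 adds nothing here with no number in this assay.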